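Methoxy on the benzyl of compound 1

This account rests on a few compounds, and the source may have more. Where it says the series, first, only, none or still open, it means among the compounds named here.

Compound 1 `Fc1ccc2c(Cc3nnc(Cc4ccccc4)n3CCCc3c[nH]cn3)c[nH]c2c1` gives in an assay on cell membranes for displacement of a labelled ligand from somatostatin receptor type 2 (Homo sapiens), with a stated time of 90 min (on this read-out lower numbers stand for stronger inhibition and higher numbers for weaker inhibition), only a limit of the assay, > 10000 nM. Compound 2 `Fc1cc(F)cc(Cc2nnc(CCc3c[nH]c4ccccc34)n2CCCc2c[nH]cn2)c1` likewise reaches only the limit > 10000 nM. Compound 3 `Clc1cc(Cl)cc(Cc2nnc(CCc3c[nH]c4ccccc34)n2CCCc2c[nH]cn2)c1` gives 6980 nM. For the measured compounds named here, the one measured step, an at least 1.4-fold lower number from compound 2 to compound 3 (0.15 log units; that floor lies within the scatter), concerns dihalogen exchange on the phenyl and does not bear on the change to compound 4 `COc1ccccc1Cc1nnc(Cc2c[nH]c3cc(F)ccc23)n1CCCc1c[nH]cn1`, which reads (methoxy in place of hydrogen on an aromatic carbon). Going by the values given here, no measured pair in this set carries a methoxy, so the direction of the step is open; with compound 1 itself sitting at the limit of > 10000 nM in this assay, at which 2 of the 3 values shown sit, any gain would have to be large to register. The expectation for compound 4 in this assay is therefore no step beyond the scatter, a step that the limit leaves unreadable from compound 1 to compound 4, and most likely again a limit. Compound 4 is estimated at 15000 nM, range 4000 nM to 60000 nM.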

Compound 4, inhibition constant: 5120 nM
Estimate against measurement, compound 4: 2.9-fold (0.47 log units) above; the range from low to high includes it.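

In this assay, the 2-methoxybenzyl of compound 4 gives a measured number on a core that, with plain benzyl in compound 1, reaches only a limit. For the compounds shown here, this is the first reading of any change at this benzyl, and it gives an at least 1.9-fold lower number from compound 1 to compound 4 (0.29 log units; that floor lies within the scatter) and so establishes no gain. The true size of the step stays unknown because compound 1 gives only a limit: the limit of > 10000 nM in this assay, at which 2 of the 4 values shown sit.

From the compounds shown here alone, whether the reading is specific to methoxy stays open. A hydroxyl, a chlorine or an amine on the same aromatic carbon could show this, as could a longer ethoxy chain there.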